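Methyl on the phenyl group of compound 1

This account rests on a few compounds, and the source may have more. Where it says the series, first, only, none or still open, it means among the compounds named here.

In a functional assay on A549 cells (Homo sapiens) for cytotoxicity, read by MTT assay, with a stated time of 72 h (a higher number here means a weaker inhibitor, a lower number a stronger inhibitor), compound 1 `Nc1ccc(Nc2nc3ccccc3nc2S(=O)(=O)c2ccccc2)cc1` gives 12900 nM, the lower of the two numeric values in the series. Compound 2 `O=S(=O)(c1ccccc1)c1nc2ccccc2nc1Nc1ccc(Cl)cc1` gives 30700 nM. Compound 3 `O=S(=O)(c1ccccc1)c1nc2ccccc2nc1Nc1ccc(C(F)(F)F)cc1` gives > 50000 nM, which is a limit of the assay and not a number.

Compound 4 `Cc1ccc(S(=O)(=O)c2nc3ccccc3nc2Nc2ccc(N)cc2)cc1` differs from compound 1 by one change: methyl in place of hydrogen on an aromatic carbon. This is methyl in place of hydrogen on an aromatic carbon, para to a large group, so phenyl becomes 4-methylphenyl.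

Going by the values given here, no measured step touches this phenyl group. All three exchange the amino, chloro or trifluoromethyl substituent elsewhere in the molecule, so they serve only as a gauge of step size in the series. The step of a 2.4-fold higher number from compound 1 to compound 2 (0.38 log units; beyond the scatter) is modest and beyond the scatter. The step of an at least 3.8-fold higher number from compound 1 to compound 3 (0.58 log units; beyond the scatter) is at least modest. The step of an at least 1.6-fold higher number from compound 2 to compound 3 (0.21 log units; that floor lies within the scatter) has a floor within the scatter. These steps give no direction for the methyl change, and a step no larger than the modest one to compound 2 is expected, most likely none beyond the scatter.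

The expected result is a 1.0-fold higher number from compound 1 to compound 4 (0.00 log units; within the scatter), with no clear direction. For compound 4 the estimated value is 13000 nM, with an expected range of 6000 nM to 28000 nM.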

Compound 4, half-maximal inhibitory concentration: 24600 nM
Compound 4: middle estimate off by 1.9-fold (0.28 log units), on the low side, and the stated range covers the measured number.
By their numbers in this assay, from the lowest: compounds 1, 4 and 2 (each within the scatter of the next, the first and the last beyond it). At a limit, above all of these: compound 3.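

In this assay, the only change shown on the phenyl group, methyl in place of hydrogen, gives a 1.9-fold higher number from compound 1 to compound 4 (0.28 log units; within the scatter), so at this position the added methyl cannot be told from the scatter. This sets the phenyl group apart from the amino group of compound 1, whose exchanges for chloro and trifluoromethyl both give steps printed as beyond the scatter, although a single methyl is only one small probe of this site. Compound 4 gets a number and does not join compound 3, whose reading is a limit of the assay and not a number: the limit of > 50000 nM in this assay, at which 1 of the 4 values shown sits.

Going by these compounds, whether this position stays as undemanding with a larger or quite different group, such as methoxy, a carboxylic acid or a longer chain such as butyl, remains open, since one methyl gives no trend. Also open, on these data alone, is whether the methyl step would read the same with chloro or trifluoromethyl in place of the amino group, where the starting readings differ and compound 3 offers only a limit.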